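Three Cytotoxicity Limits Meet a Pyridine Sulfonamide

The source may hold more compounds than are shown below. What is called first, only, known or untested is meant among the compounds shown, and "the series" means these compounds.

Compound 3 `Cc1cccc(S(=O)(=O)N2CCC(N3CCC(C)CC3)CC2)c1` is one of three sulfonamides that have been measured in an ADME assay on HCT-116 cells (Homo sapiens) for cytotoxicity, read by CellTiter-Glo, with a stated time of 72 h; a higher number here means a weaker inhibitor, a lower number a stronger inhibitor. In this assay compound 3 gives > 5000 nM, which is a limit of the assay and not a number. Compound 1 `CC1CCN(C2CCN(S(=O)(=O)c3cccc(-c4ccc(F)cc4)c3)CC2)CC1` likewise gives only a limit, > 5000 nM. Compound 2 `COc1ccc(-c2cccc(S(=O)(=O)N3CCC(N4CCC(C)CC4)CC3)c2)cc1` also gives a limit, > 5000 nM. Because (the limit of > 5000 nM in this assay, at which 3 of the 3 values shown sit), the steps a step that the two limits leave unreadable from compound 1 to compound 2, a step that the two limits leave unreadable from compound 1 to compound 3 and a step that the two limits leave unreadable from compound 2 to compound 3 cannot be read, and compound 3 stands at the limit shared by all three.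

Compound 4 `CC1CCN(C2CCN(S(=O)(=O)c3cccnc3)CC2)CC1` differs from compound 3 in one place: pyridin-3-yl in place of 3-methylphenyl on a sulfonyl sulfur. Among the measured compounds shown here, no measured step bears on this change, since every step among the three is unreadable, so nothing in the numbers points to a direction beyond the scatter. Compound 4 is therefore expected to sit near the same limit, and the step from it is estimated at a step that the limit leaves unreadable from compound 3 to compound 4. Compound 4 is expected to give 8000 nM, within a range from 3000 nM to 25000 nM, most likely reported again as a limit.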

Compound 4, half-maximal inhibitory concentration: > 10000 nM
Compound 4: only a limit was reported; the forecaster's own chance of this, stated with the estimate: 85%; at least 1.2-fold (0.09 log units) between middle value and limit.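

In this assay compound 4 gives > 10000 nM, which is a limit of the assay and not a number. Set against the limit of compound 3, it yields no readable step. The compounds shown leave open what effect, if any, pyridin-3-yl in place of 3-methylphenyl has in this assay.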